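The source may report more compounds than this note shows. Statements on the series, on what has been measured and on what is new or still open speak of the compounds shown alone.

In a functional assay on cells (Peritoneal macrophage, Mus musculus) for cytotoxicity, with a stated time of 24 h (a higher number here means that more compound is tolerated, a lower number that less compound is tolerated), compound 1 `COc1ccc(S(=O)(=O)N(CC(N)=O)c2ccc(N(CC(N)=O)S(=O)(=O)c3ccc(NC(C)=O)cc3)c3ccccc23)cc1` gives > 50000 nM, a limit of the assay. Compound 2 `CCC(=O)Nc1ccc(S(=O)(=O)N(CC(N)=O)c2ccc(N(CC(N)=O)S(=O)(=O)c3ccc(OC)cc3)c3ccccc23)cc1` gives > 50000 nM, also a limit. Compound 3 `COc1ccc(S(=O)(=O)N(CC(N)=O)c2ccc(N(CC(N)=O)S(=O)(=O)c3ccc(NC(=O)CN4CCCCC4)cc3)c3ccccc23)cc1` gives > 100000 nM, likewise a limit. Every value shown for the series is thus a limit: compound 3 sits at the limit of > 100000 nM in this assay, at which 1 of the 3 values shown sits, the other two at the limit of > 50000 nM in this assay, at which 2 of the 3 values shown sit. Compound 4 `COc1ccc(S(=O)(=O)N(CC(N)=O)c2ccc(N(CC(N)=O)S(=O)(=O)c3ccc(NC(=O)CN4CCC(C)CC4)cc3)c3ccccc23)cc1` differs from compound 3 by methyl in place of hydrogen on a saturated ring carbon. The measured steps a step that the two limits leave unreadable from compound 1 to compound 2, a step that the two limits leave unreadable from compound 1 to compound 3 and a step that the two limits leave unreadable from compound 2 to compound 3 all concern the chain carbon bound to the carbonyl carbon, none touches the piperidin-1-yl ring, and none has a readable size, so the expected step in this assay is a step that the limit leaves unreadable from compound 3 to compound 4, nothing beyond the scatter. Compound 4 is estimated at 150000 nM, within 60000 nM to 400000 nM, most likely again reported only as a limit.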

Compound 4, half-maximal cytotoxic concentration: > 50000 nM
Compound 4: no number, only a limit (the forecaster's own chance of this, stated with the estimate: 85%); the middle value does not contradict the limit.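

In this assay, among the compounds shown here, compound 4 gives > 50000 nM, again a limit, so no step from compound 1, compound 2 or compound 3 to compound 4 can be read. Whether any of these changes shifts cytotoxicity stays open: no compound shown has a numeric value.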